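The source may hold more compounds than are shown below. What is called first, only, known or untested is meant among the compounds shown, and "the series" means these compounds.

Among the measured compounds shown here, compound 1 `COc1cc(/C=C2\CCC/C(=C\c3ccc([N+](=O)[O-])cc3)C2=O)ccc1O` holds the highest of the two numbers so far in a functional assay on HSG cells (Homo sapiens) for cytotoxicity; on this read-out higher numbers stand for lower toxicity in this test and lower numbers for higher toxicity in this test: compound 1 gives 11000 nM. For the measured compounds named here, its nearest neighbour, compound 2 `COc1ccc(/C=C2\Cc3ccccc3/C(=C\c3ccc([N+](=O)[O-])cc3)C2=O)cc1OC`, gives 4400 nM in this assay, a gap beyond the scatter; the two differ in more than one place, so the pair shows only that compound 2 sits at the lower number. Compound 3 `COc1ccc(/C=C2\CCC/C(=C\c3ccc([N+](=O)[O-])cc3)C2=O)cc1` is the next compound to be tested. Relative to compound 1 the change is 4-methoxyphenyl in place of 4-hydroxy-3-methoxyphenyl on a double-bonded chain carbon bound to a double-bonded ring carbon. Going by the values given here, no single-change step of this kind has been measured, and compound 2 cannot serve as a guide, as its core also differs from that of compound 1. The expectation for compound 3 in this assay is therefore a step of a 1.4-fold lower number from compound 1 to compound 3 (0.14 log units; within the scatter), within or close to the scatter, if anything toward a lower number. Compound 3 is estimated at 8000 nM in this assay, with a range from 3000 nM to 20000 nM.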

Compound 3, half-maximal cytotoxic concentration: > 400000 nM
Compound 3: only a limit was reported; the forecaster's own chance of this, stated with the estimate: 5%; middle value at least 50-fold (1.69 log units) away from the limit.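

In this assay, exchanging 4-hydroxy-3-methoxyphenyl for 4-methoxyphenyl on a double-bonded chain carbon bound to a double-bonded ring carbon gives an at least 36-fold higher number from compound 1 to compound 3 (1.56 log units; beyond the scatter), so this position on the shared core can carry a large step, which the pair of compound 1 and compound 2 could not show. Compound 3 stands as a limit of the assay and not as a number: the limit of > 400000 nM in this assay, at which 1 of the 3 values shown sits. Among the compounds shown here, the change takes the count of hydrogen-bond donors in this group from 1 to 0 and the count of hydrogen-bond acceptors from 2 to 1, and this single step is the only reading of this position so far.

Going by these compounds, the step does not separate the two differences between these groups, so the part played by each stays open. A 4-hydroxyphenyl or 4-aminophenyl group at this place on the core of compound 1 would be needed to tell them apart.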